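Swapping an aryl group in a pair of cytotoxic acrylic acids

The compounds below may be only part of what the source reports. "The series", "measured", "known", "first", "only" and "open" are said of these compounds alone.

Measured so far:
compound 1 `CC/C(=C(/c1ccc(/C=C/C(=O)O)c(OC)c1)c1ccc2[nH]ncc2c1)c1ccccc1`: 31 nM
compound 2 `CC/C(=C(/c1ccc(/C=C/C(=O)O)cc1)c1ccc2[nH]ncc2c1)c1cccc(C#N)c1`: 100 nM

In a functional assay on MCF7 cells (Homo sapiens) for cytotoxicity, read by CellTiter-Glo, with a stated time of 5 days (on this read-out lower numbers stand for stronger inhibition and higher numbers for weaker inhibition), compound 2 gives 100 nM and compound 1 gives 31 nM. Among the two numbers, compound 2 stands highest, and the gap to compound 1 lies beyond the scatter. Compound 3 `CC/C(=C(/c1ccc(/C=C/C(=O)O)cc1)c1ccc2[nH]ncc2c1)c1cccnc1C` is not yet measured; it differs from compound 2 by 2-methylpyridin-3-yl in place of 3-cyanophenyl on a double-bonded chain carbon bound to a double-bonded chain carbon and a saturated chain carbon. Within the data shown here, no measured pair shows this change, so the expectation rests on compound 2 alone, and only a small step, if any, beyond the scatter is expected in this assay. Compound 3 is expected to give 150 nM, with a range from 50 nM to 500 nM, and the estimated step of a 1.5-fold higher number from compound 2 to compound 3 (0.18 log units; within the scatter) points toward slightly weaker inhibition.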

Compound 3, half-maximal inhibitory concentration: 200 nM
Estimate against measurement, compound 3: 1.3-fold (0.12 log units) below; low and high end bracket the measured number.
By their numbers in this assay, from the lowest: compound 1; then compounds 2 and 3 (each within the scatter of the next).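

In this assay, putting 2-methylpyridin-3-yl in place of 3-cyanophenyl gives a 2.0-fold higher number from compound 2 to compound 3 (0.30 log units; within the scatter), so the two aromatic groups cannot be told apart at this position. The swap removes the nitrile and brings in a ring nitrogen and a methyl, yet the numbers stay within the scatter of each other. Nothing measured here explains this result. Still open is whether the methyl or the ring nitrogen matters on its own, as the plain pyridin-3-yl group is not among the compounds shown. A group such as an amine or a longer chain on this ring also remains untested in what is shown.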